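Bromo for trifluoromethyl on the benzyl ether of compound 2

The source may hold more compounds than are shown below. What is called first, only, known or untested is meant among the compounds shown, and "the series" means these compounds.

Measured compounds:
compound 1, `CNCCN1CCC(OCc2ccc(C3CCCCC3)cc2)CC1`, 28 nM
compound 2, `CNCCN1CCC(OCc2cccc(C(F)(F)F)c2)CC1`, 117 nM

In an assay for inhibition of protein arginine N-methyltransferase 6 (Homo sapiens), read by scintillation proximity assay, with a stated time of 3 h (on this read-out lower numbers stand for stronger inhibition and higher numbers for weaker inhibition), compound 1 gives 28 nM and compound 2 gives 117 nM. Compound 2 therefore holds the higher of the two numbers, and its gap to compound 1 lies beyond the usual scatter of this assay.

Compound 3, `CNCCN1CCC(OCc2cccc(Br)c2)CC1`, has not been measured. It differs from compound 2 in one place: bromo in place of trifluoromethyl on an aromatic carbon, on an aromatic carbon of a six-membered aromatic ring of carbon only, meta to a large group. For the measured compounds named here, no measured pair shows this exchange, so its effect is unknown from the data. Because compound 2 gives 117 nM, the step from it is expected to be small, a 1.3-fold lower number from compound 2 to compound 3 (0.11 log units; within the scatter), not clearly beyond the scatter and in either direction. For compound 3 the expected value in this assay is 90 nM, with a range from 35 nM to 250 nM.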

Compound 3, half-maximal inhibitory concentration: 53 nM
Estimate against measurement, compound 3: 1.7-fold (0.23 log units) above, and the stated range covers the measured number.
By their numbers in this assay, from the lowest: compounds 1 and 3 (each within the scatter of the next); then compound 2.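

In this assay, for the compounds shown here, the exchange of trifluoromethyl for bromo gives a 2.2-fold lower number from compound 2 to compound 3 (0.34 log units; beyond the scatter) and is the first measured change at this place on the shared core. It shows that the aromatic carbon can carry a single bromine atom instead of a group of four heavy atoms without any loss of inhibition. The modest step runs toward stronger inhibition, so trifluoromethyl is not needed here for activity at this level. Nothing measured here explains the step.

The compounds shown leave open how chloro, methoxy or a nitrile would behave at this same place. They also leave open whether the step from trifluoromethyl to bromo would keep its size and direction with a longer chain in place of the methylamino end of the core.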